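Moving the Methyl Pair Around the Aryl Ring

This account rests on a few compounds, and the source may have more. Where it says the series, first, only, none or still open, it means among the compounds named here.

Three amides sharing one core have been measured in a functional assay on HL-60 cells (Homo sapiens) for inhibition, read by MTT assay, with a stated time of 72 h; a higher number here means a weaker inhibitor, a lower number a stronger inhibitor. Compound 1 `Cc1nc(-c2ccccc2)c(C(=O)N2CCN(c3ccccc3)CC2)o1` gives 39.1 nM, compound 2 `Cc1nc(-c2ccccc2)c(C(=O)N2CCN(c3ccc(C)c(C)c3)CC2)o1` gives 43 nM, and compound 3 `Cc1nc(-c2ccccc2)c(C(=O)N2CCN(c3cccc(F)c3)CC2)o1` gives 45 nM. Compound 3 holds the highest of the three numbers, yet its gaps to compound 2 and compound 1 both lie within the scatter, so the three are indistinguishable in this assay.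

Compound 4 `Cc1ccc(C)c(N2CCN(C(=O)c3oc(C)nc3-c3ccccc3)CC2)c1` differs from compound 3 as follows: 2,5-dimethylphenyl in place of 3-fluorophenyl on an amine nitrogen in a ring. The relevant precedents are a 1.1-fold higher number from compound 1 to compound 2 (0.04 log units; within the scatter) and a 1.0-fold higher number from compound 2 to compound 3 (0.02 log units; within the scatter), both within the scatter, showing that this aryl group tolerates phenyl, dimethylphenyl and fluorophenyl alike. Compound 4 is therefore expected to give 43 nM in this assay, with a range of 20 nM to 95 nM, an expected step of a 1.0-fold lower number from compound 3 to compound 4 (0.02 log units; within the scatter) that stays within the scatter.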

Compound 4, half-maximal inhibitory concentration: 31.3 nM
Compound 4: the middle estimate sits 1.4-fold (0.14 log units) above what was measured; measured number inside the range.
By their numbers in this assay, from the lowest: compounds 4, 1, 2 and 3 (each within the scatter of the next).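

In this assay, 2,5-dimethylphenyl also stays within the scatter of each earlier aryl group (a 1.4-fold lower number from compound 3 to compound 4 (0.16 log units; within the scatter); a 1.4-fold lower number from compound 2 to compound 4 (0.14 log units; within the scatter); a 1.2-fold lower number from compound 1 to compound 4 (0.10 log units; within the scatter)). Across these four compounds, the aryl group on the amine nitrogen in a ring therefore accepts a different placement of the methyl pair as readily as it accepts phenyl or 3-fluorophenyl. No measurement at hand accounts for this.

The compounds shown carry only methyl or fluoro on that phenyl ring. They leave open whether a carboxylic acid or an amine there, or a pyridine ring in its place, would hold the same level.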